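The compounds below may be only part of what the source reports. "The series", "measured", "known", "first", "only" and "open" are said of these compounds alone.

Among the measured compounds shown here, in a functional assay on MCF-10A cells (Homo sapiens) for antiproliferative activity, with a stated time of 48 h (a lower number here means that less compound is needed, a higher number that more compound is needed for the effect), compound 1 `COc1ccc2nc(C)cc(NCc3ccccc3)c2c1` gives 25900 nM, the highest of the three numbers measured so far. Compound 2 `COc1ccc2nc(C)cc(NCC3CCCN(C)C3)c2c1` gives 6400 nM, and compound 3 `COc1ccc(CNc2cc(C)nc3ccc(OC)cc23)cc1` gives 7000 nM. Compound 4 `COc1cccc(CNc2cc(C)nc3ccc(OC)cc23)c1` is still unmeasured and differs from compound 1 by one change: methoxy in place of hydrogen on an aromatic carbon. The closest guide is a 3.7-fold lower number from compound 1 to compound 3 (0.57 log units; beyond the scatter), which is also methoxy in place of hydrogen on an aromatic carbon. The other measured step, a 4.0-fold lower number from compound 1 to compound 2 (0.61 log units; beyond the scatter), replaces phenyl instead and bears on this change only loosely. With a single comparable step to go on, a modest lowering of the number is expected in this assay. The expected step is a 2.6-fold lower number from compound 1 to compound 4 (0.41 log units; beyond the scatter). For compound 4 the estimated value is 10000 nM, with an expected range of 4500 nM to 22000 nM.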

Compound 4, half-maximal effective concentration: 9700 nM
Compound 4: the middle estimate sits 1.0-fold (0.01 log units) above what was measured; the measured number falls inside the stated range.
By their numbers in this assay, from the lowest: compounds 2, 3 and 4 (each within the scatter of the next); then compound 1.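

In this assay, methoxy on the aromatic carbon meta to a large group also lowers the number, a 2.7-fold lower number from compound 1 to compound 4 (0.43 log units; beyond the scatter). The lowering seen with compound 3 is therefore not tied to a single carbon of that ring: compound 3 gives 7000 nM and compound 4 gives 9700 nM, values within the scatter of each other. Nothing measured here explains this step.

From the compounds shown here alone, whether a chlorine atom or an ethoxy group on that same carbon would match methoxy remains open. So does whether a second methoxy on the ring would lower the number further.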